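Extending the hydroxyethyl chain of compound 3 to a carboxylic acid

This account rests on a few compounds, and the source may have more. Where it says the series, first, only, none or still open, it means among the compounds named here.

Of the compounds shown here, three sharing one core have been measured in an assay on A7R5 cells for displacement of a labelled ligand from Endothelin-1 receptor (Rattus norvegicus); on this read-out lower numbers stand for stronger inhibition and higher numbers for weaker inhibition. Compound 1 `COC(=O)CCCc1onc(NS(=O)(=O)c2ccc(C(C)(C)C)cc2)c1Sc1cccc(OC)c1` gives 400 nM, compound 2 `COc1cccc(Sc2c(NS(=O)(=O)c3ccc(C(C)(C)C)cc3)noc2CCC/C=N/O)c1` gives 1500 nM, and compound 3 `COc1cccc(Sc2c(NS(=O)(=O)c3ccc(C(C)(C)C)cc3)noc2CCO)c1` gives 770 nM. Among the measured compounds shown here, compound 3 sits within the scatter of both neighbours: there is a 1.9-fold higher number from compound 1 to compound 3 (0.28 log units; within the scatter) and a 1.9-fold lower number from compound 2 to compound 3 (0.29 log units; within the scatter), while a 3.8-fold higher number from compound 1 to compound 2 (0.57 log units; beyond the scatter) is the only step beyond the scatter.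

Compound 4 `COc1cccc(Sc2c(NS(=O)(=O)c3ccc(C(C)(C)C)cc3)noc2CCCC(=O)O)c1` differs from compound 3 by carboxymethyl in place of hydroxy on a saturated chain carbon, two bonds along the chain from an aromatic carbon. For the measured compounds named here, the step that bears on this is the one from compound 1 to compound 3, where the (methoxycarbonyl)methyl group was cut back to hydroxy and gave a 1.9-fold higher number from compound 1 to compound 3 (0.28 log units; within the scatter). Going by the values given here, compound 4 reverses that shortening but carries a carboxylic acid rather than the methyl ester of compound 1, so there is no measured example of this exact change. Because compound 1 gives 400 nM, a small step toward a lower number is expected, within the scatter. Compound 4 is therefore estimated at 500 nM, in the range 200 nM to 1500 nM, which amounts to an expected 1.5-fold lower number from compound 3 to compound 4 (0.19 log units; within the scatter).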

Compound 4, half-maximal inhibitory concentration: 4300 nM
Compound 4: middle estimate off by 8.6-fold (0.93 log units), on the low side, outside the stated range (above it).
By their numbers in this assay, from the lowest: compounds 1, 3 and 2 (each within the scatter of the next, the first and the last beyond it); then compound 4.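

In this assay, the 3-carboxypropyl chain costs far more than any earlier change at this position: carboxymethyl in place of hydroxy gives a 5.6-fold higher number from compound 3 to compound 4 (0.75 log units; beyond the scatter), and the group on the same chain carbon in compound 2 also gives way to the acid with a 2.9-fold higher number from compound 2 to compound 4 (0.46 log units; beyond the scatter). The sharpest contrast comes from a single methyl, since hydrogen in place of methyl on the oxygen next to the carbonyl group gives an 11-fold higher number from compound 1 to compound 4 (1.03 log units; beyond the scatter), so among these compounds chain length alone does not set the number. Nothing available here gives a reason for this loss.

Going by these compounds, it remains open whether a shorter acid, the 2-carboxyethyl chain, would read like compound 4. Also open, on these data alone, is whether an ethyl ester or a primary amide in place of the carboxylic acid would read closer to compound 1 or to compound 4.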